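The compounds below may be only part of what the source reports. "The series", "measured", "known", "first", "only" and "open" are said of these compounds alone.

Measured so far:
- compound 1 `CCOC(=O)/C=C/c1ccncc1-c1ccc2[nH]ccc2c1`: > 10000 nM
- compound 2 `Cn1ccc2cc(-c3cnccc3/C=C/C(=O)O)ccc21`: > 10000 nM
- compound 3 `CNC(=O)/C=C/c1ccncc1-c1ccc2[nH]ccc2c1`: > 10000 nM

In a functional assay on MCF7 cells (Homo sapiens) for inhibition, read by sulforhodamine B assay, with a stated time of 72 h (on this read-out lower numbers stand for stronger inhibition of growth and higher numbers for weaker inhibition of growth), compound 3 gives > 10000 nM, which is a limit and not a number. Compound 1 gives > 10000 nM, also a limit. Compound 2 gives > 10000 nM, again a limit. Compound 3 therefore stands with the other two: the limit of > 10000 nM in this assay, at which 3 of the 3 values shown sit.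

Compound 4 `O=C(O)/C=C/c1ccncc1-c1ccc2[nH]ccc2c1` differs from compound 3 in one place, with hydroxy in place of methylamino on a carbonyl carbon. Among the measured compounds shown here, the one measured step that bears on this change is a step that the two limits leave unreadable from compound 1 to compound 3, at the same carbonyl carbon, and its size cannot be read. For the measured compounds named here, no measured step therefore offers a size to carry over, and no step beyond the scatter is expected in this assay, with growth inhibition expected to stay weak. The expected step is a step that the limit leaves unreadable from compound 3 to compound 4. For compound 4 the estimate is 15000 nM, with an expected range from 8000 nM to 30000 nM, most likely reported only as a limit.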

Compound 4, concentration for 50% growth inhibition: > 10000 nM
Compound 4: no number, only a limit (the forecaster's own chance of this, stated with the estimate: 90%); the middle value is on the limit's open side.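

In this assay, no step from compound 1, compound 2 or compound 3 to compound 4 can be read, and all four compounds give only a limit: the limit of > 10000 nM in this assay, at which 4 of the 4 values shown sit.

The compounds shown leave open how strongly any of them inhibits growth, and whether any of these single changes alters it.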